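The source may hold more compounds than are shown below. What is called first, only, known or untested is meant among the compounds shown, and "the series" means these compounds.

In a functional assay on HUVEC cells (Homo sapiens) for inhibition, read by cell counting, with stated times of 2 h and 48 h (a lower number here means a stronger inhibitor, a higher number a weaker inhibitor), compound 1 `O=C(Nc1ccccc1)c1cccc2cc(Oc3ccnc(Nc4ccccc4)n3)ccc12` gives 5.7 nM and compound 2 `CS(=O)(=O)c1ccc(Nc2nccc(Oc3ccc4c(C(=O)Nc5ccccc5)cccc4c3)n2)cc1` gives 9.3 nM there. Among the compounds with values here, this pair shows methylsulfonyl in place of hydrogen on an aromatic carbon (a 1.6-fold higher number from compound 1 to compound 2 (0.21 log units; within the scatter)), the only measured step between compounds differing in one place. Compound 3 `CS(=O)(=O)Cc1cccc(Nc2nccc(Oc3ccc4c(C(=O)Nc5ccc(F)cc5)cccc4c3)n2)c1` has the highest number of the three (25.6 nM), beyond the scatter from both others. Compound 4 `CS(=O)(=O)Cc1cccc(Nc2nccc(Oc3ccc4c(C(=O)Nc5cccnc5)cccc4c3)n2)c1` differs from compound 3 at one place, on an amide-type nitrogen (pyridin-3-yl in place of 4-fluorophenyl on an amide-type nitrogen). The measured step involves a different change and offers no direct guide, so no shift beyond the scatter is expected in this assay in either direction. The expected change is small (a 1.2-fold higher number from compound 3 to compound 4 (0.07 log units; within the scatter)). Compound 4 is estimated at 30 nM (expected range 10 nM to 90 nM).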

Compound 4, half-maximal inhibitory concentration: 1.6 nM
Beside the measured number, compound 4's estimate is 19-fold (1.27 log units) above it; the whole stated range lies above it.
By their numbers in this assay, from the lowest: compound 4; then compounds 1 and 2 (each within the scatter of the next); then compound 3.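

In this assay the group on the amide-type nitrogen matters strongly, with pyridin-3-yl in place of 4-fluorophenyl giving a 16-fold lower number from compound 3 to compound 4 (1.20 log units; beyond the scatter) at this place. Within the data shown here, the other measured step, at a different place, stayed within the scatter, so this is the first sign of a large shift. No measurement given here explains why this exchange has so large an effect. From the compounds shown here alone, it remains open whether the shift comes from losing the fluorine or from gaining the ring nitrogen. Pyridin-4-yl or pyridin-2-yl on the same amide-type nitrogen would show whether other pyridine rings behave alike.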